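Antiproliferation notes: spirooxindole triazole series

A few compounds are considered here, and "the series" means these few. Any claim that something is new, unique, unknown or untested is made for them only; others in the source may bear on it.

Measured so far in an ADME assay on L02 cells (Homo sapiens) for antiproliferative activity, read by MTT assay, with a stated time of 48 h; a lower number here means a stronger inhibitor, a higher number a weaker inhibitor:
- compound 1, `N#CC1=C(N)Oc2c(c3nc4ccccc4nc3c3ccccc23)C12C(=O)N(Cc1cnnn1-c1ccc([N+](=O)[O-])cc1)c1ccccc12`: > 50000 nM
- compound 2, `N#CC1=C(N)Oc2c(N)cc3nc4ccccc4nc3c2C12C(=O)N(Cc1cnnn1-c1ccc(Cl)cc1)c1ccccc12`: > 50000 nM

The value for compound 1 is a limit of this assay, not a number. The value for compound 2 is likewise a limit of this assay. Among the compounds with values here, both values sit at the limit of > 50000 nM in this assay, at which 2 of the 2 values shown sit, so compound 2 stands at the same limit as the only other measured compound, and no ordering between the two can be read from these numbers.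

Compound 3 is `Cc1cc(C)cc(-n2nncc2CN2C(=O)C3(C(C#N)=C(N)Oc4c(N)cc5nc6ccccc6nc5c43)c3ccccc32)c1`, not yet measured in this assay. It differs from compound 2 as follows: 3,5-dimethylphenyl in place of 4-chlorophenyl on an aromatic nitrogen.

Within the data shown here, no step between measured compounds is available, and compound 2 itself gives only a limit, so no computed step exists to lean on. The expectation is that compound 3 also reports a limit rather than a number in this assay, that is, a step of none beyond the scatter, as the estimated step that the limit leaves unreadable from compound 2 to compound 3 indicates. The estimate for compound 3 in this assay is 80000 nM, with a range from 30000 nM to 250000 nM.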

Compound 3, half-maximal inhibitory concentration: > 50000 nM
Compound 3 gave a limit, no number (the forecaster's own chance of this, stated with the estimate: 85%); the middle value does not contradict the limit.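

In this assay compound 3 gives > 50000 nM, which is a limit of the assay and not a number. No step from compound 2 to compound 3 can be read: the limit of > 50000 nM in this assay, at which 3 of the 3 values shown sit.

The compounds shown leave open whether 3,5-dimethylphenyl in place of 4-chlorophenyl on the aromatic nitrogen makes any difference in this assay.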